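Three Sulfonamides at the Assay Limit and a Fourth

A few compounds are considered here, and "the series" means these few. Any claim that something is new, unique, unknown or untested is made for them only; others in the source may bear on it.

In an assay on isolated protein for inhibition of malate dehydrogenase, mitochondrial (Sus scrofa), with stated times of 45 min and 30 min (on this read-out lower numbers stand for stronger inhibition and higher numbers for weaker inhibition), the three measured compounds share a sulfonamide between two aromatic portions, and none gives a number. Compound 1 `O=S(=O)(Nc1ccc(-c2nc3ccccc3o2)cc1)c1cccc(F)c1` sits at a limit of the assay, > 63000 nM. Compound 2 `C=Cc1ccc(S(=O)(=O)Nc2ccc3oc(-c4ccccc4)nc3c2)cc1` likewise gives only a limit, > 63000 nM. Compound 3 `O=S(=O)(Nc1ccc2oc(-c3ccccc3)nc2c1)c1ccc(F)c(C(F)(F)F)c1` also returns a limit, > 63000 nM. Where compound 2 stands among these numbers is therefore only this: its value is a limit, as are the two other values shown, and because of the limit of > 63000 nM in this assay, at which 3 of the 3 values shown sit, no ordering among the three can be read from the data.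

Compound 4 `O=S(=O)(Nc1ccc2oc(-c3ccccc3)nc2c1)c1cccc(O)c1` has not been measured in this assay. It differs from compound 2 in one place: 3-hydroxyphenyl in place of 4-vinylphenyl on a sulfonyl sulfur whose other neighbour is the sulfonamide nitrogen. Within the data shown here, no step between measured compounds is known, so no direction can be drawn from a measured pair. With every shown value at the limit, no step beyond the scatter is expected, and the expected step is a number no higher from compound 2 to compound 4 (the limit leaves the size open). Compound 4 is therefore expected to give about 63000 nM, within a range from 20000 nM to 200000 nM, most likely again reported only as a limit.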

Compound 4, half-maximal inhibitory concentration: > 63000 nM
Compound 4 ended at the assay's limit; the forecaster's own chance of this, stated with the estimate: 85%; the middle value lies on the limit itself.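

No step can be read from compound 2 to compound 4 with its 3-hydroxyphenyl in place of 4-vinylphenyl, and no other new step can be read either, because both results are limits and not numbers: the limit of > 63000 nM in this assay, at which 4 of the 4 values shown sit.

The compounds shown leave open what structure, if any, would give a measurable value in this assay.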